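A few compounds are considered here, and "the series" means these few. Any claim that something is new, unique, unknown or untested is made for them only; others in the source may bear on it.

In a functional assay on MCF7 cells (Homo sapiens) for cytotoxicity, read by MTT assay, with a stated time of 6 days (on this read-out lower numbers stand for an effect already at smaller amounts and higher numbers for an effect only at larger amounts of compound), compound 1 (`COc1cc(-c2cc(=O)c3cc(O)ccc3o2)cc(OC)c1OC`) gives > 25 ug/mL, which is a limit and not a number. Compound 3 (`COc1cc(-c2cc(=O)c3cc(O)ccc3o2)cc(OC)c1O`) gives > 25 ug/mL, also a limit. Together these two make up (the limit of > 25 ug/mL in this assay, at which 2 of the 3 values shown sit). Among the measured compounds shown here, compound 2 (`COc1cc(-c2cc(=O)c3cc(O)ccc3o2)cc(OC)c1O[Si](C)(C)C(C)(C)C`) is the only one with a measured number, at 2.01 ug/mL.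

Compound 4 (`COc1ccc2oc(-c3cc(OC)c(OC)c(OC)c3)cc(=O)c2c1`) changes compound 1 at one place, hydroxy to methoxy: methyl in place of hydrogen on an oxygen on an aromatic ring.

The closest measured step is the same kind of exchange in reverse at another oxygen on an aromatic ring, and it cannot be sized: a step that the two limits leave unreadable from compound 1 to compound 3. The large steps, an at least 12-fold lower number from compound 1 to compound 2 (1.09 log units; beyond the scatter) and an at least 12-fold higher number from compound 2 to compound 3 (1.09 log units; beyond the scatter), involve the silicon-bearing group rather than a methyl, so they offer little guide to this change. No step beyond the scatter is therefore expected in this assay, and no direction can be assigned. The estimated step is a step that the limit leaves unreadable from compound 1 to compound 4. Compound 4 is most likely to reach the limit as well, and its value is estimated at 30 ug/mL, within an expected range of 12 ug/mL to 60 ug/mL.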

Compound 4, concentration for half-maximal effect: > 25 ug/mL
Compound 4 gave a limit, no number; the forecaster's own chance of this, stated with the estimate: 70%; the middle value does not contradict the limit.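

In this assay compound 4 gives > 25 ug/mL, a limit and not a number. Compound 1 also stands at a limit, so no step between these two compounds can be read: the limit of > 25 ug/mL in this assay, at which 3 of the 4 values shown sit.

The compounds shown leave open whether hydroxy to methoxy at this oxygen changes the read-out at all.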